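The compounds below may be only part of what the source reports. "The series", "measured", "known", "first", "only" and "open" are said of these compounds alone.

Compound 1 `Cc1cc(S(=O)(=O)/N=C(\N)n2nccc2-c2ccccc2)c(SCc2ccc(Cl)cc2)cc1Cl` gives 3000 nM in a functional assay on HeLa cells (Homo sapiens) for cytotoxicity, read by MTT assay, with a stated time of 72 h; on this read-out lower numbers stand for stronger inhibition and higher numbers for weaker inhibition. Compound 2 `Cc1cccc(CSc2cc(Cl)c(C)cc2S(=O)(=O)/N=C(\N)n2nccc2-c2ccccc2)c1` gives 8000 nM. Compound 3 `Cc1ccc(CSc2cc(Cl)c(C)cc2S(=O)(=O)/N=C(\N)n2nccc2-c2ccccc2)cc1` gives 17000 nM.

Compound 2 stands second highest of these three numbers: a 2.7-fold higher number from compound 1 to compound 2 (0.43 log units; beyond the scatter) and a 2.1-fold higher number from compound 2 to compound 3 (0.33 log units; beyond the scatter). Compound 4 `Cc1cccc(CSc2cc(Cl)c(C)cc2S(=O)(=O)/N=C(\N)n2nc(C)cc2-c2ccccc2)c1` differs from compound 2 by methyl in place of hydrogen on an aromatic carbon. For the measured compounds named here, no measured step touches the five-membered ring; the known steps concern the group on the saturated chain carbon bound to a sulfur, a 2.7-fold higher number from compound 1 to compound 2 (0.43 log units; beyond the scatter) and a 2.1-fold higher number from compound 2 to compound 3 (0.33 log units; beyond the scatter), and the chloro to methyl swap, a 5.7-fold higher number from compound 1 to compound 3 (0.75 log units; beyond the scatter), all modest. They therefore give no direction for this change, and a step within the scatter is expected. Compound 4 is estimated at 8000 nM, within 3000 nM to 25000 nM, which would be expected as no change at the digits printed from compound 2 to compound 4 (within the scatter).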

Compound 4, half-maximal inhibitory concentration: 155000 nM
Beside the measured number, compound 4's estimate is 19-fold (1.29 log units) below it; measured number outside the range, above it.
By their numbers in this assay, from the lowest: compound 1; then compound 2; then compound 3; then compound 4.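

The five-membered ring is not a silent site: methyl in place of hydrogen on an aromatic carbon, next to the ring nitrogen, gives a 19-fold higher number from compound 2 to compound 4 (1.29 log units; beyond the scatter) in this assay and so much weaker inhibition. The earlier steps shown here, all at other sites, were modest, so this one added carbon matters more than any of them. Nothing measured here explains the loss.

From the compounds shown here alone, whether any group at this carbon costs as much remains open; a fluoro, ethyl or methoxy group there would test this. Also open, going by these compounds, is whether methyl has the same effect on compound 1.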